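The source may report more compounds than this note shows. Statements on the series, on what has been measured and on what is new or still open speak of the compounds shown alone.

Three compounds share one core and differ only in the aromatic ring attached para to the large group. Compound 1 `Cn1nc2c(=O)n(CC3(O)CCN(Cc4ccc(-c5ccoc5)cc4Cl)CC3)cnc2c1-c1ccc(CN)cc1` carries a furan-3-yl and in an assay on isolated protein for inhibition of ubiquitin carboxyl-terminal hydrolase 7 (Homo sapiens), with stated times of 30 min and 2 h (a higher number here means a weaker inhibitor, a lower number a stronger inhibitor), compound 1 gives 177 nM. Compound 2 `Cn1nc2c(=O)n(CC3(O)CCN(Cc4ccc(-c5ccncc5)cc4Cl)CC3)cnc2c1-c1ccc(CN)cc1` carries a pyridin-4-yl and compound 2 gives 257 nM. Compound 3 `Cn1nc2c(=O)n(CC3(O)CCN(Cc4ccc(-c5ccsc5)cc4Cl)CC3)cnc2c1-c1ccc(CN)cc1` carries a thiophen-3-yl and compound 3 gives 59.5 nM, the lowest of the three numbers; the step of a 3.0-fold lower number from compound 1 to compound 3 (0.47 log units; beyond the scatter) and the step of a 4.3-fold lower number from compound 2 to compound 3 (0.64 log units; beyond the scatter) both lie beyond the scatter, while a 1.5-fold higher number from compound 1 to compound 2 (0.16 log units; within the scatter) does not.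

Compound 4 `Cn1nc2c(=O)n(CC3(O)CCN(Cc4ccc(-c5cnco5)cc4Cl)CC3)cnc2c1-c1ccc(CN)cc1` differs from compound 3 in one place: 1,3-oxazol-5-yl in place of thiophen-3-yl on an aromatic carbon. The two steps that bear on this are those into compound 3, a 3.0-fold lower number from compound 1 to compound 3 (0.47 log units; beyond the scatter) and a 4.3-fold lower number from compound 2 to compound 3 (0.64 log units; beyond the scatter), both modest and both favouring thiophen-3-yl over a ring with more hetero atoms. On that basis the step of a 2.7-fold higher number from compound 3 to compound 4 (0.43 log units; beyond the scatter) is expected to be a modest rise, in the direction of compounds 1 and 2. Compound 4 is therefore estimated at 160 nM, with a range from 60 nM to 420 nM.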

Compound 4, half-maximal inhibitory concentration: 71.6 nM
The estimate for compound 4 lay 2.2-fold (0.35 log units) above the measured number, within the range that was stated.
By their numbers in this assay, from the lowest: compounds 3 and 4 (each within the scatter of the next); then compounds 1 and 2 (each within the scatter of the next).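

In this assay, the step of a 1.2-fold higher number from compound 3 to compound 4 (0.08 log units; within the scatter) shows that sulfur is not needed at this position, para to a large group: a 1,3-oxazol-5-yl, with 2 hetero atoms in its five-membered aromatic ring, is level with the thiophen-3-yl. The oxazole also separates from the other two rings, with the steps of a 3.6-fold lower number from compound 2 to compound 4 (0.56 log units; beyond the scatter) and a 2.5-fold lower number from compound 1 to compound 4 (0.39 log units; beyond the scatter). Oxygen in a five-membered aromatic ring therefore does not by itself bring the higher number of compound 1, as the earlier compounds might have suggested.

No measurement shown accounts for this ordering of the rings. Going by these compounds, it remains open how a plain phenyl ring, a ring bearing an amine or a carboxylic acid would compare with compound 3 and compound 4 at this position.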